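Cytotoxicity at the Limit: From Compound 3 to Compound 4

The compounds below may be only part of what the source reports. "The series", "measured", "known", "first", "only" and "open" are said of these compounds alone.

Compound 1 `C=CC(C)(C)c1[nH]c2ccc(C[C@H](O)C(C)(C)O)cc2c1/C=C1\NC(=O)[C@H](C)NC1=O`: > 200000 nM
Compound 2 `C=CC(C)(C)c1[nH]c2ccc(C[C@H](O)C(C)(C)OC)cc2c1/C=C1\NC(=O)[C@H](C)NC1=O`: > 200000 nM
Compound 3 `C=CC(C)(C)c1[nH]c2ccccc2c1/C=C1\NC(=O)[C@H](C)NC1=O`: > 200000 nM

All three measured compounds were tested in an ADME assay on MDCK cells (Canis lupus familiaris) for cytotoxicity, read by CellTiter-Glo, with a stated time of 40 h; a higher number here means that more compound is tolerated, a lower number that less compound is tolerated. Compound 1 gives > 200000 nM, which is a limit of the assay and not a number. Compound 2 likewise gives > 200000 nM, again a limit. Compound 3 gives > 200000 nM, also a limit. Compound 3 therefore stands where every value shown stands, at the limit of > 200000 nM in this assay, at which 3 of the 3 values shown sit, and nothing separates it from the others.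

The steps among the measured compounds carry no readable size: a step that the two limits leave unreadable from compound 1 to compound 2, a step that the two limits leave unreadable from compound 1 to compound 3 and a step that the two limits leave unreadable from compound 2 to compound 3. Removing the whole side chain from compound 1 or compound 2 to give compound 3 left the read-out at the limit.

Compound 4 `C=CC(C)(C)c1[nH]c2ccc(CC=C(C)C)cc2c1/C=C1\NC(=O)[C@H](C)NC1=O` differs from compound 3 by 3-methylbut-2-en-1-yl in place of hydrogen on an aromatic carbon. Among the compounds with values here, no measured step bears on this change with a readable size; the only guidance is that compound 1 and compound 2, which also carry a chain at this position, sit at the limit like compound 3. The step from compound 3 to compound 4 is expected to be a number no higher from compound 3 to compound 4 (the limit leaves the size open), none beyond the scatter. Compound 4 is therefore expected to give about 200000 nM, in a range from 80000 nM to 400000 nM, most likely again reported only as a limit.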

Compound 4, half-maximal cytotoxic concentration: > 200000 nM
Compound 4: only a limit was reported (the forecaster's own chance of this, stated with the estimate: 80%); the middle value lies on the limit itself.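

In this assay compound 4 gives > 200000 nM, which is a limit of the assay and not a number. No step from compound 1, compound 2 or compound 3 to compound 4 can be read: the limit of > 200000 nM in this assay, at which 4 of the 4 values shown sit.

The compounds shown leave open whether any of the four differs from the others in how much is tolerated.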